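The compounds below may be only part of what the source reports. "The series", "measured", "known", "first", "only" and "open" are said of these compounds alone.

Working notes on the series.

Compound 1, `COc1ccc(C(=O)Nc2cc(-c3ccccc3)nn2-c2ccccc2)cc1`, is the reference point. In an assay on HEK293 cells for displacement of a labelled ligand from metabotropic glutamate receptor 5 (Rattus norvegicus) (on this read-out lower numbers stand for stronger inhibition and higher numbers for weaker inhibition), compound 1 gives 420 nM. Among the measured compounds shown here, the only other measured member, compound 2, `N#Cc1ccc(C(=O)/N=c2\cc(-c3ccccc3)n(C(=O)c3ccc(C#N)cc3)n2-c2ccccc2)cc1`, gives 5230 nM in this assay; compound 1 therefore stands at the lowest of the two numbers, and the gap to compound 2 lies beyond the usual scatter. For the measured compounds named here, compound 2 differs from compound 1 in more than one place, so no single step between the two can be read off.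

Compound 3, `O=C(CC1CCCC1)Nc1cc(-c2ccccc2)nn1-c1ccccc1`, is the next member to be measured in this assay. Its relation to compound 1 is cyclopentylmethyl in place of 4-methoxyphenyl on a carbonyl carbon. Going by the values given here, no measured pair shows a change of this kind, so there is no directly comparable step to draw on. The expectation is that compound 3 comes out weaker than compound 1 in this assay, by a step of modest size, with the estimated step from compound 1 to compound 3 being a 3.6-fold higher number from compound 1 to compound 3 (0.55 log units; beyond the scatter). For compound 3 the estimated inhibition constant is 1500 nM, with a range from 400 nM to 6000 nM.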

Compound 3, inhibition constant: > 10000 nM
Compound 3 ended at the assay's limit (the forecaster's own chance of this, stated with the estimate: 15%); middle value at least 6.6-fold (0.82 log units) away from the limit.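

Among the compounds shown here, the change from 4-methoxyphenyl to cyclopentylmethyl on a carbonyl carbon gives the first single-place step in this assay, an at least 23-fold higher number from compound 1 to compound 3 (1.37 log units; beyond the scatter), so this position is sensitive to the group it carries, which the comparison of compound 1 with compound 2 could not show. Compound 3 stands at a limit of the assay, > 10000 nM, and this is not a number. The step therefore sets only a lower bound on the size of the change, and its full size cannot be read: the limit of > 10000 nM in this assay, at which 1 of the 3 values shown sits.

The single step changes several things together: the six-membered aromatic ring gives way to a five-membered non-aromatic ring, the oxygen and its hydrogen-bond acceptor leave, and the heavy-atom count falls, so the compounds shown do not say which of these matters. From the compounds shown here alone, whether an unsubstituted phenyl, a pyridine ring, a benzyl group or a cyclohexyl group on the same carbonyl carbon would stay closer to compound 1 remains open.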